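A few compounds are considered here, and "the series" means these few. Any claim that something is new, unique, unknown or untested is made for them only; others in the source may bear on it.

In an ADME assay on microsomes (Rattus norvegicus) for metabolic stability (a higher number here means that the compound lasts longer, a lower number that the compound disappears faster), three compounds on the shared core have been measured. Compound 1 `O=C(c1ccccc1)N1CCC(C(=O)N2N=CCC2c2ccccc2)CC1` gives 0.0833 h, compound 2 `CCC(=O)N1CCC(C(=O)N2N=CCC2c2ccccc2)CC1` gives 1.07 h, and compound 3 `O=C(C1CCN(C(=O)C(F)(F)F)CC1)N1N=CCC1c1ccccc1` gives 0.483 h, which places compound 3 second highest of the three. Compound 4 `O=C(c1cn[nH]c1)N1CCC(C(=O)N2N=CCC2c2ccccc2)CC1` is still unmeasured. Its difference from compound 3 is 1H-pyrazol-4-yl in place of trifluoromethyl on a carbonyl carbon, in words 1H-pyrazol-4-yl in place of trifluoromethyl on a carbonyl carbon.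

All measured steps fall at this same place: a 13-fold higher number from compound 1 to compound 2 (1.11 log units; beyond the scatter) is large, while a 5.8-fold higher number from compound 1 to compound 3 (0.76 log units; beyond the scatter) and a 2.2-fold lower number from compound 2 to compound 3 (0.35 log units; beyond the scatter) are modest. Going by the values given here, compound 1, the only measured compound with an aromatic ring there, is lowest at 0.0833 h, so some downward movement is expected, as the step of a 5.8-fold higher number from compound 1 to compound 3 (0.76 log units; beyond the scatter) read in reverse suggests. Among the compounds with values here, no 1H-pyrazol-4-yl compound has been measured, so this comparison is weak and the range stays wide.

The estimated step is a 1.4-fold lower number from compound 3 to compound 4 (0.14 log units; within the scatter), expected to be lower but within the scatter. For compound 4 the expected half-life is 0.35 h, with an estimated range of 0.1 h to 1.2 h.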

Compound 4, half-life: > 2.75 h
Compound 4: no number, only a limit; the forecaster's own chance of this, stated with the estimate: 3%; middle value at least 7.8-fold (0.89 log units) away from the limit.
By their numbers in this assay, from the lowest: compound 1; then compound 3; then compound 2. At a limit, above all of these: compound 4.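

In this assay, compound 4 has no number, only a limit of the assay: the limit of > 2.75 h in this assay, at which 1 of the 4 values shown sits.

An aromatic ring on this carbonyl carbon is thus not tied to a short half-life: replacing phenyl with 1H-pyrazol-4-yl, itself a five-membered aromatic ring, gives an at least 33-fold higher number from compound 1 to compound 4 (1.51 log units; beyond the scatter). The position also holds more than ethyl and trifluoromethyl had shown, with an at least 5.6-fold higher number from compound 3 to compound 4 (0.75 log units; beyond the scatter) and an at least 2.5-fold higher number from compound 2 to compound 4 (0.40 log units; beyond the scatter), so 1H-pyrazol-4-yl now ranks above both groups in this series.

Going by these compounds, how far compound 4 lies past its limit remains unknown, so the full size of these steps cannot be read. On these data alone, whether a pyridine ring or an amine on this carbonyl carbon would hold the half-life as well also stays open.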